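Working notes: 4-chlorophenyl to 3-chlorophenyl amide

The compounds below may be only part of what the source reports. "The series", "measured", "known", "first", "only" and "open" are said of these compounds alone.

- compound 1 `CN(C)C(=O)c1cc2cnc(Nc3ccc(NC(=O)C4(C(=O)Nc5ccc(F)cc5)CC4)cc3)nc2n1C1CCCC1` gives 86.6%
- compound 2 `CN(C)C(=O)c1cc2cnc(Nc3ccc(NC(=O)C4(C(=O)Nc5ccc(Cl)cc5)CC4)cc3)nc2n1C1CCCC1` gives 24.7%

In a functional assay on A549 cells (Homo sapiens) for inhibition, read by CCK-8 assay, with a stated time of 72 h, tested at 1 uM (on this read-out higher numbers stand for more inhibition of growth at the one concentration tested and lower numbers for less inhibition of growth), compound 2 stands at 24.7% and is the lower of the two measured compounds. The change to compound 3 `CN(C)C(=O)c1cc2cnc(Nc3ccc(NC(=O)C4(C(=O)Nc5cccc(Cl)c5)CC4)cc3)nc2n1C1CCCC1` is 3-chlorophenyl in place of 4-chlorophenyl on an amide-type nitrogen. For the measured compounds named here, one measured step bears on it: a number 61.9 percentage points lower from compound 1 to compound 2 (beyond the scatter), a large step for chloro in place of fluoro on an aromatic carbon. Going by the values given here, that step replaces one atom and does not shift a chlorine, so it shows only that a change on this ring can be large. It gives no direct size or direction here. A moderate rise in this assay is expected, with wide uncertainty, since compound 2 at 24.7% leaves more room upward than downward. The estimated step is a number 10.3 percentage points higher from compound 2 to compound 3 (beyond the scatter). For compound 3 the expected value is 35% within an estimated range of 10% to 70%.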

Compound 3, percent growth inhibition at one concentration: 8.3%
The estimate for compound 3 lay 26.7 percentage points above the measured number, and the stated range ends above it.
By their numbers in this assay, from the lowest: compound 3; then compound 2; then compound 1.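

Moving the chlorine, with the same atoms joined differently, still counts in this assay: the change gives a number 16.4 percentage points lower from compound 2 to compound 3 (beyond the scatter), so on this amide-bound ring the place of the halogen matters as well as its identity, which the step from fluoro to chloro could not show. The step of a number 78.3 percentage points lower from compound 1 to compound 3 (beyond the scatter) is large, and both chlorophenyl amides stand well under the 4-fluorophenyl amide of compound 1. No measurement shown here accounts for either fall.

From the compounds shown here alone, whether a fluoro group moved in the same way would also lose activity remains open, since only chlorine has been shifted so far. Going by these compounds, how an unsubstituted phenyl or a methoxy group on this ring would compare also remains open, so the two halogens cannot yet be set against any other substituent.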